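Growth inhibition of dienone triazole coumarin hybrids in prostate cells

The source may hold more compounds than are shown below. What is called first, only, known or untested is meant among the compounds shown, and "the series" means these compounds.

Compound 1 `COc1cc(/C=C/C(=O)/C=C/c2ccccc2)ccc1OCc1cn(CCCOc2cc(=O)oc3ccccc23)nn1`: "not active" (no number reported)
Compound 2 `COc1ccccc1/C=C/C(=O)/C=C/c1ccc(OCc2cn(CCCOc3cc(=O)oc4ccccc34)nn2)c(OC)c1`: "not active" (no number reported)
Compound 3 `COc1ccc(/C=C/C(=O)/C=C/c2ccc(OCc3cn(CCOc4cc(=O)oc5ccccc45)nn3)c(OC)c2)cc1OC`: 19%

Three compounds share one core and were tested in a functional assay on PC-3 cells (Homo sapiens) for inhibition, read by sulforhodamine B assay, with a stated time of 48 h, tested at 50 uM; on this read-out higher numbers stand for more inhibition of growth at the one concentration tested and lower numbers for less inhibition of growth. For the measured compounds named here, compound 3 gives 19%, and this is the only number reported; the two further entries, compound 1 and compound 2, returned no number at all. Going by the values given here, compound 3 therefore stands alone with a single, modest reading and no measured step links it to any neighbour.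

Compound 4 `COc1cc(/C=C/C(=O)/C=C/c2ccccc2)ccc1OCc1cn(CCOc2cc(=O)oc3ccccc23)nn1` differs from compound 3 at one position: phenyl in place of 3,4-dimethoxyphenyl on a double-bonded chain carbon bound to a double-bonded chain carbon. Among the compounds with values here, no step between measured compounds is known, so the size of the move from compound 3 to compound 4 cannot be read off a precedent. Compound 4 also carries a phenyl group, as does compound 1, and the chain that joins the triazole to the coumarin in compound 4 is the shorter one seen in compound 3.

Compound 1, which also carries a phenyl, gives "not active" (no number reported) in this assay. In view of that reading, the step of a number 9 percentage points lower from compound 3 to compound 4 (within the scatter) is expected to be small and, if anything, downward. Compound 4 is estimated at 10%, within 0% to 25%, with a fair chance that only a statement of inactivity is returned.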

Compound 4, percent growth inhibition at one concentration: 10%
Compound 4: middle estimate and measured number agree at the digits printed; the measured number falls inside the stated range.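

For the compounds shown here, the first measured step at this position comes in this assay: phenyl in place of 3,4-dimethoxyphenyl on a double-bonded chain carbon bound to a double-bonded chain carbon gives a number 9 percentage points lower from compound 3 to compound 4 (within the scatter), so the two compounds cannot be told apart on this read-out. Going by these compounds alone, the 3,4-dimethoxyphenyl group, with its 2 hydrogen-bond acceptors and 10 heavy atoms, is therefore not needed for a number to be returned here, which the earlier compounds could not show; compound 1, which carries the same phenyl but a different linking chain, gives "not active" (no number reported), and no size can be read for that difference. Nothing available bears on why these readings fall as they do.

The compounds shown leave open whether any group at this place can move the reading beyond the usual scatter, for example an aminophenyl, a carboxyphenyl or a pyridyl in place of phenyl. They also leave open how a longer chain at this place would read, and whether compound 3 and compound 4 would differ at any other concentration in this assay.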